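The source may hold more compounds than are shown below. What is called first, only, known or untested is meant among the compounds shown, and "the series" means these compounds.

For the measured compounds named here, compound 3 `Cc1cc(C)c(S(=O)(=O)N2CCN(c3ccc(C(=O)/C=C/c4ccccc4)cc3)CC2)c(C)c1` gives 55.5% in a functional assay on the whole organism (strain Kunming) for inhibition, with Mus musculus as the target, with a stated time of 1 h, at a dose of 40 mg/kg by the oral route (a higher number here means more inhibition at the dose given (going by the name of the read-out), a lower number less inhibition), the highest of the three numbers so far, though compound 2 `O=C(/C=C/c1ccccc1)c1ccc(N2CCN(S(=O)(=O)c3ccc(Br)cc3)CC2)cc1`, which gives 47.4%, sits within the scatter of it. Compound 1 `O=C(/C=C/c1ccccc1)c1ccc(N2CCN(S(=O)(=O)c3ccc4ccccc4c3)CC2)cc1` gives 35%. The steps of a number 20.5 percentage points higher from compound 1 to compound 3 (beyond the scatter) and a number 8.1 percentage points higher from compound 2 to compound 3 (within the scatter) each change only the group on the sulfonyl sulfur. Compound 4 `CCCCc1ccc(S(=O)(=O)N2CCN(c3ccc(C(=O)/C=C/c4ccccc4)cc3)CC2)cc1` carries the change (4-butylphenyl in place of 2,4,6-trimethylphenyl on a sulfonyl sulfur). The group that enters is a phenyl ring bearing a single group, as in compound 2, so the comparison of compound 2 with compound 3 bears most directly, and that step lay within the scatter. A small downward step, within the scatter, is therefore expected, a number 7.5 percentage points lower from compound 3 to compound 4 (within the scatter). Compound 4 is estimated at 48%, with a range from 32% to 64%.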

Compound 4, a percentage reported as inhibition, in the whole organism at one dose (the size of the read-out at that dose, not a potency): 24%
Estimate against measurement, compound 4: 24 percentage points above; the measured number lies below the stated range.
By their numbers in this assay, from the lowest: compound 4; then compound 1; then compounds 2 and 3 (each within the scatter of the next).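

The step of a number 31.5 percentage points lower from compound 3 to compound 4 (beyond the scatter) is the largest yet at this position in this assay, although both groups are carbon-only aromatic groups with no hydrogen-bond donors or acceptors. The step of a number 23.4 percentage points lower from compound 2 to compound 4 (beyond the scatter) shows that butyl and bromo on an aromatic carbon are not interchangeable here, and with a number 11 percentage points lower from compound 1 to compound 4 (beyond the scatter) the 4-butylphenyl group ranks under the naphthalen-2-yl group too. No information here explains this fall.

Whether the low number follows from chain length stays open, since an ethyl or a hexyl chain in place of butyl is not among the compounds shown. On these data alone, the effect of an amine or a carboxylic acid on that ring also remains unknown.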